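The source may hold more compounds than are shown below. What is called first, only, known or untested is meant among the compounds shown, and "the series" means these compounds.

Compound 1 `C[C@H](C(=O)N[C@H](C#N)CC(N)=O)N(Cc1ccc(-c2cc(F)cc(F)c2)cc1)S(C)(=O)=O` gives 9250 nM in an assay on isolated protein for inhibition of legumain (Homo sapiens), with stated times of 2 min and 60 min; a lower number here means a stronger inhibitor, a higher number a weaker inhibitor. Compound 2 `C[C@H](C(=O)N[C@H](C#N)CC(N)=O)N(Cc1ccc(-c2cccc(C(F)(F)F)c2)cc1)S(C)(=O)=O` reaches only the limit of this assay, > 10000 nM, which is not a number. The step of an at least 1.0-fold higher number from compound 1 to compound 2 (0.03 log units; that floor lies within the scatter) is thus known only as a floor, and it comes from the limit of > 10000 nM in this assay, at which 1 of the 2 values shown sits. Compound 3 `C[C@H](C(=O)N[C@H](C#N)CC(N)=O)N(Cc1ccc(-c2ccc(F)c(F)c2)cc1)S(C)(=O)=O` is not yet measured; it differs from compound 2 by 3,4-difluorophenyl in place of 3-(trifluoromethyl)phenyl on an aromatic carbon. Compound 3 also carries a difluorophenyl, like compound 1, so the expected result rests on compound 1 and its value 9250 nM. For compound 3 the estimated step is an at least 1.1-fold lower number from compound 2 to compound 3 (0.04 log units; that floor lies within the scatter). Compound 3 is expected to give 9000 nM, within 3000 nM to 30000 nM.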

Compound 3, half-maximal inhibitory concentration: 6300 nM
Compound 3: the middle estimate sits 1.4-fold (0.15 log units) above what was measured, and the stated range covers the measured number.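

Exchanging 3,5-difluorophenyl for 3,4-difluorophenyl gives a 1.5-fold lower number from compound 1 to compound 3 (0.17 log units; within the scatter), so in this assay these two fluorine patterns on the ring cannot be told apart. Exchanging 3-(trifluoromethyl)phenyl for 3,4-difluorophenyl gives an at least 1.5-fold lower number from compound 2 to compound 3 (0.20 log units; that floor lies within the scatter), and this size is only a floor, set by a limit of the assay: the limit of > 10000 nM in this assay, at which 1 of the 3 values shown sits.

As far as these compounds go, whether any group at this position can move the number beyond the scatter remains open. A plain phenyl, or a ring carrying an amine or a carboxylic acid, would test this.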